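A few compounds are considered here, and "the series" means these few. Any claim that something is new, unique, unknown or untested is made for them only; others in the source may bear on it.

Compound 1 `Cn1nnc(-c2cc(-c3ccc(Cl)c(Cl)c3)ncn2)n1`: in an assay on isolated protein for inhibition of kynurenine 3-monooxygenase (Homo sapiens), read by LC-MS (a higher number here means a weaker inhibitor, a lower number a stronger inhibitor), compound 1 gives > 10000 nM, which is a limit and not a number.
Compound 2 `CS(=O)(=O)Nc1cc(-c2ccc(Cl)c(Cl)c2)ncn1`: compound 2 gives > 10000 nM, again a limit and not a number.

Because both values sit at the limit of > 10000 nM in this assay, at which 2 of the 2 values shown sit, the step that the two limits leave unreadable from compound 1 to compound 2 cannot be read, and compound 2 stands only as showing no measurable inhibition. Compound 3 `Clc1ccc(-c2cc(-n3cccn3)ncn2)cc1Cl` carries 1H-pyrazol-1-yl in place of methanesulfonamido on an aromatic carbon. Within the data shown here, no measured step bears on this change, so no direction or size can be drawn from the data. Compound 3 is expected to give about 20000 nM, within 4000 nM to 100000 nM. The expected step is a step that the limit leaves unreadable from compound 2 to compound 3.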

Compound 3, half-maximal inhibitory concentration: > 10000 nM
Compound 3 was reported as a limit; the forecaster's own chance of this, stated with the estimate: 80%; the middle value is on the limit's open side.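

Compound 3 gives > 10000 nM, again a limit and not a number. No step to compound 3 from compound 1 or compound 2 can be read: the limit of > 10000 nM in this assay, at which 3 of the 3 values shown sit.

The compounds shown leave open which group on the shared core, if any, would give measurable inhibition in this assay.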